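Moving the trifluoromethyl on a cytotoxicity read-out

The source may hold more compounds than are shown below. What is called first, only, known or untested is meant among the compounds shown, and "the series" means these compounds.

Compound 1, `O=C(N/N=C/Nc1ccc(C(=O)O)c(O)c1)c1cccc(F)c1`, gives 934000 nM in an ADME assay on HepG2 cells (Homo sapiens) for cytotoxicity, read by MTT assay; on this read-out higher numbers stand for weaker inhibition and lower numbers for stronger inhibition.
Compound 2, `O=C(O)c1ccc(N/C=N/NC(=O)c2ccccc2F)cc1O`, gives 1210000 nM in this assay.
Compound 3, `O=C(N/N=C/N1CCN(c2cc3c(cc2F)c(=O)c(C(=O)O)cn3C2CC2)CC1)c1ccc(C(F)(F)F)cc1`, gives 347000 nM in this assay.

Among these three, compound 3 stands at the lowest number, with compound 1 nearest and compound 2 furthest, both separated from it by more than the scatter. Compound 4, `O=C(N/N=C/N1CCN(c2cc3c(cc2F)c(=O)c(C(=O)O)cn3C2CC2)CC1)c1cccc(C(F)(F)F)c1`, is not yet measured and differs from compound 3 only in where the trifluoromethyl sits on the aryl ring: 3-(trifluoromethyl)phenyl in place of 4-(trifluoromethyl)phenyl on a carbonyl carbon. Among the measured compounds shown here, the one comparable step that has been measured is a shift of a fluorine on the aryl ring of the carbonyl, a 1.3-fold higher number from compound 1 to compound 2 (0.11 log units; within the scatter), which stayed within the scatter. On that basis compound 4 is expected to stay close to compound 3, and its step of a 1.0-fold higher number from compound 3 to compound 4 (0.00 log units; within the scatter) is estimated as nothing beyond the scatter. Compound 4 is therefore estimated at 350000 nM, within a range of 150000 nM to 800000 nM.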

Compound 4, half-maximal inhibitory concentration: > 322000 nM
Compound 4: a limit, no number; the forecaster's own chance of this, stated with the estimate: 10%; the middle value does not contradict the limit.
By their numbers in this assay, from the lowest: compound 3; then compounds 1 and 2 (each within the scatter of the next).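

Among the compounds shown here, compound 4 gives > 322000 nM, which is a limit and not a number, so no step from compound 3 to compound 4 can be read. From the compounds shown here alone, whether 3-(trifluoromethyl)phenyl in place of 4-(trifluoromethyl)phenyl on a carbonyl carbon shifts the number in this assay beyond the scatter stays open.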